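Replacing a phenyl with a thiazolyl on an amide nitrogen

The source may hold more compounds than are shown below. What is called first, only, known or untested is meant among the compounds shown, and "the series" means these compounds.

Compound 2 `CC(C)(C)c1cc(C(=O)Nc2ccccc2)n(Cc2ccccc2)n1` stands highest in a physicochemical assay for lipophilicity, read by HPLC, at pH 3.0 (on this read-out higher numbers stand for higher lipophilicity and lower numbers for lower lipophilicity), where compound 2 gives 4.7. Compound 1 `COc1ccc(C(=O)Nc2nc(CN)cs2)cc1` gives 0.9 in this assay, and compound 3 `NCc1csc(NC(=O)c2cn(Cc3ccccc3)nn2)n1` gives 1.1, both well beyond the scatter below compound 2. The unmeasured compound 4 `CNCc1csc(NC(=O)c2cc(C(C)(C)C)nn2Cc2ccccc2)n1` differs from compound 2 in one place: 4-((methylamino)methyl)-1,3-thiazol-2-yl in place of phenyl on an amide-type nitrogen. Among the compounds with values here, no step between two measured compounds matches this change, but compound 1 and compound 3, which carry a related aminomethyl thiazolyl group, sit far lower. The step from compound 2 to compound 4 is therefore expected to be a large drop, a number 2.80 log units lower from compound 2 to compound 4 (beyond the scatter). Compound 4 is estimated at 1.9, within a range from 1.2 to 2.7.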

Compound 4, distribution coefficient: 2.6
Estimate against measurement, compound 4: 0.70 log units below, and the stated range covers the measured number.
By their numbers in this assay, from the lowest: compounds 1 and 3 (each within the scatter of the next); then compound 4; then compound 2.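

In this assay, 4-((methylamino)methyl)-1,3-thiazol-2-yl in place of phenyl on an amide-type nitrogen gives a large fall, a number 2.10 log units lower from compound 2 to compound 4 (beyond the scatter), with the rest of the molecule unchanged. The earlier compounds shown here could not show this, as no two of them differed in only one place. Nothing available explains the size of this step.

On these data alone, how much of the step belongs to the ring and how much to its methylaminomethyl arm remains open. A thiazol-2-yl group with no arm, or one carrying hydroxymethyl instead, would separate the two.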